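A few compounds are considered here, and "the series" means these few. Any claim that something is new, unique, unknown or untested is made for them only; others in the source may bear on it.

Measured in a physicochemical assay for solubility, read by nephelometry, at pH 7.4; on this read-out higher numbers stand for higher solubility and lower numbers for lower solubility:
- Compound 1 `COc1cccc(NC(=O)c2nnn(Cc3ccncc3)c2N)c1`: < 12000 nM (a limit of the assay, not a number)
- Compound 2 `COc1cccc(NC(=O)c2nnn(Cc3ccc(C#N)cc3)c2N)c1`: 216000 nM
- Compound 3 `COc1cccc(NC(=O)c2nnn(Cc3ccccc3)c2N)c1`: 16000 nM

Compound 3 holds the lower of the two true numbers, and the gap between them is a 14-fold lower number from compound 2 to compound 3 (1.13 log units; beyond the scatter). Against the limit of compound 1, the comparison reads an at least 1.3-fold higher number from compound 1 to compound 3 (0.12 log units; that floor lies within the scatter), so those two cannot be ranked. The other comparison with that limit is an at least 18-fold higher number from compound 1 to compound 2 (1.25 log units; beyond the scatter).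

Compound 4 `COc1cccc(NC(=O)c2nnn(Cc3ccc(C4CC4)cc3)c2N)c1` keeps the shared core and turns the phenyl of compound 3 into 4-cyclopropylphenyl: cyclopropyl in place of hydrogen on an aromatic carbon. The measured step that bears most directly on this change is the one at an aromatic carbon, a 14-fold lower number from compound 2 to compound 3 (1.13 log units; beyond the scatter). It is large, but it concerns cyano rather than cyclopropyl, so it shows how far a change on this ring can move the number without setting a direction for the new group. The large rise appears only with the cyano of compound 2 (216000 nM), so in this assay only a small downward step is expected, possibly none beyond the scatter. The expected change is a 1.3-fold lower number from compound 3 to compound 4 (0.12 log units; within the scatter). For compound 4 the estimate is 12000 nM, with an expected range of 5000 nM to 40000 nM. A report only as a limit is also expected to be quite possible, given (the limit of < 12000 nM in this assay, at which 1 of the 3 values shown sits).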

Compound 4, solubility: 79000 nM
For compound 4 the middle estimate is 6.6-fold (0.82 log units) below the measured one; the whole stated range lies below it.
By their numbers in this assay, from the lowest: compound 3; then compound 4; then compound 2. At a limit, below all of these: compound 1.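

Before compound 4, the only rise on this ring came from the nitrile of compound 2, but cyclopropyl on the same aromatic carbon in this assay also raises the number, with a 4.9-fold higher number from compound 3 to compound 4 (0.69 log units; beyond the scatter), so a rise here does not need a cyano group. The new group does not reach the nitrile's level, with a 2.7-fold lower number from compound 2 to compound 4 (0.44 log units; beyond the scatter), which separates the two groups at this carbon beyond the scatter. Compound 1 is known only as a limit, so an at least 6.5-fold higher number from compound 1 to compound 4 (0.81 log units; beyond the scatter) gives only a floor, and compound 4 comes out as a true number rather than joining it: the limit of < 12000 nM in this assay, at which 1 of the 4 values shown sits.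

Apart from hydrogen, the compounds shown carry only cyano and cyclopropyl at this carbon, so they leave open what an amine, a carboxylic acid or a longer chain such as propyl would do to the number there. Nothing shown says why both groups raise the number, and one example of each sets no rule for this ring.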